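The compounds below may be only part of what the source reports. "The series", "measured", "known", "first", "only" and "open" are said of these compounds alone.

Compound 1 `COc1ccc2nc(Nc3nc(Nc4ccc(S(N)(=O)=O)cc4)ncc3F)sc2c1`: > 50000 nM
Compound 2 `COc1ccc2nc(Nc3ccnc(Nc4ccc(S(N)(=O)=O)cc4)n3)sc2c1`: 3030 nM
Compound 3 `NS(=O)(=O)c1ccc(Nc2nccc(Nc3nc4ccccc4s3)n2)cc1`: 3100 nM

In a functional assay on PC-3 cells (Homo sapiens) for antiproliferative activity, read by MTT assay, with a stated time of 48 h (a lower number here means a stronger inhibitor, a higher number a weaker inhibitor), compound 2 gives 3030 nM. In this assay compound 3 gives 3100 nM. Compound 1 is reported in this assay only as a limit, > 50000 nM.

The two cores differ by hydrogen in place of methoxy on an aromatic carbon, which gave a 1.0-fold higher number from compound 2 to compound 3 (0.01 log units; within the scatter). From compound 2 to compound 1 the change is fluoro in place of hydrogen on an aromatic carbon, and it made an at least 16-fold higher number from compound 2 to compound 1 (1.21 log units; beyond the scatter).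

Compound 4 `NS(=O)(=O)c1ccc(Nc2nccc(Nc3nc4ccc(F)cc4s3)n2)cc1` is not yet measured; it is compound 3 with fluoro in place of hydrogen on an aromatic carbon. This is the same kind of change as in compound 1, not the same: there the fluoro sits on a six-membered aromatic ring with 2 nitrogen, ortho to a large group, two atoms from the ring nitrogen and para to a large group, whereas in compound 4 it sits on a six-membered aromatic ring of carbon only, part of a fused system of two rings, meta and para to a fused ring. The step from compound 3 to compound 4 is expected to be small, a 1.1-fold higher number from compound 3 to compound 4 (0.05 log units; within the scatter), resting on the same place having shown a 1.0-fold higher number from compound 2 to compound 3 (0.01 log units; within the scatter). Compound 4 is estimated at 3500 nM, between 1500 nM and 9000 nM.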

Compound 4, half-maximal inhibitory concentration: 920 nM
The estimate for compound 4 lay 3.8-fold (0.58 log units) above the measured number; the whole stated range lies above it.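

In this assay fluoro in place of hydrogen gave a 3.4-fold lower number from compound 3 to compound 4 (0.53 log units; beyond the scatter) and fluoro in place of methoxy gave a 3.3-fold lower number from compound 2 to compound 4 (0.52 log units; beyond the scatter) with the fluoro on a six-membered aromatic ring of carbon only. The change therefore did not carry over from one core to the other: the same change on two cores in this assay, an at least 16-fold higher number (1.21 log units; beyond the scatter) from compound 2 to compound 1 and a 3.4-fold lower number (0.53 log units; beyond the scatter) from compound 3 to compound 4, at least 55-fold (1.74 log units) apart, beyond the scatter of two such steps. On these data alone, compound 1 is reported only as a limit, > 50000 nM, so the full size of its step is unknown, and its fluoro sits on a different ring, so the comparison does not separate the place of the fluoro from the core.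

The compounds shown leave open how chloro or trifluoromethyl would read at the place of the fluoro in compound 4. They also leave open what an amine would give at that place.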